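The source may hold more compounds than are shown below. What is called first, only, known or untested is meant among the compounds shown, and "the series" means these compounds.

Compound 1 `Cc1ccc(N2CCN(C(=O)[C@@H]3CN(C4CCOCC4)C[C@H]3c3ccc(Cl)cc3)CC2)c([C@@H](NC(=O)CN)C(C)C)c1`: 9.1 nM
Compound 2 `Cc1ccc(N2CCN(C(=O)[C@@H]3CN(C4CCOCC4)C[C@H]3c3ccc(Cl)cc3)CC2)c([C@@H](NC(=O)[C@H](C)N)C(C)C)c1`: 5.2 nM
Compound 3 `Cc1ccc(N2CCN(C(=O)[C@@H]3CN(C4CCOCC4)C[C@H]3c3ccc(Cl)cc3)CC2)c([C@@H](NC(=O)[C@@H](C)N)C(C)C)c1`: 17 nM

These three share one core and differ only in the chain attached to the amide carbonyl. In a functional assay on CHO cells for agonist activity at Melanocortin receptor 4 (Homo sapiens), read by cAMP accumulation (a higher number here means that more compound is needed for the effect, a lower number that less compound is needed), compound 3 gives 17 nM, the highest of the three numbers; compound 1 sits nearest with 9.1 nM and compound 2 furthest with 5.2 nM. Compound 4 `Cc1ccc(N2CCN(C(=O)[C@@H]3CN(C4CCOCC4)C[C@H]3c3ccc(Cl)cc3)CC2)c([C@@H](NC(=O)CCN)C(C)C)c1` carries 2-aminoethyl in place of 1-aminoethyl on a carbonyl carbon, so the stereocentre that separates compound 2 from compound 3 disappears. Going by the values given here, two measured steps bear on this: a 1.9-fold higher number from compound 1 to compound 3 (0.27 log units; within the scatter) and a 3.3-fold higher number from compound 2 to compound 3 (0.51 log units; beyond the scatter), the latter resting on (the fact that compounds 2 and 3 differ only in the configuration as drawn). Both are small, and the change to compound 4 rearranges the same atoms rather than adding or removing any. Since compound 1 gives 9.1 nM, the number for compound 4 is expected to lie nearby. The expected step is then a 1.4-fold lower number from compound 3 to compound 4 (0.15 log units; within the scatter), not beyond the scatter. Compound 4 is estimated at 12 nM, between 4 nM and 40 nM.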

Compound 4, half-maximal effective concentration: 6 nM
Compound 4: middle estimate off by 2.0-fold (0.30 log units), on the high side; low and high end bracket the measured number.
By their numbers in this assay, from the lowest: compounds 2, 4, 1 and 3 (each within the scatter of the next, the first and the last beyond it).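

In this assay, replacing 1-aminoethyl with 2-aminoethyl on the carbonyl carbon gives a 2.8-fold lower number from compound 3 to compound 4 (0.45 log units; beyond the scatter), but only a 1.2-fold higher number from compound 2 to compound 4 (0.06 log units; within the scatter). Against the shorter chain, aminomethyl in place of amino gives a 1.5-fold lower number from compound 1 to compound 4 (0.18 log units; within the scatter), so this position accepts the longer chain without a change beyond the scatter. Compound 3 stands apart from compound 2 and compound 4, and only one stereocentre separates it from compound 2: the fact that compounds 2 and 3 differ only in the configuration as drawn. Still open, on these data alone, is whether a 3-aminopropyl chain would hold these numbers. Also open, as far as these compounds go, is whether a hydroxyl or a carboxylic acid could replace the amine.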